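The source may report more compounds than this note shows. Statements on the series, on what has been measured and on what is new or still open speak of the compounds shown alone.

Read-outs so far in a functional assay on MCF7 cells (Homo sapiens) for cytotoxicity, read by MTT assay, with a stated time of 96 h (on this read-out higher numbers stand for weaker inhibition and lower numbers for stronger inhibition), are these.
- compound 1 `COc1cc(C(=O)c2cn(-c3ccccc3)cc2-c2ccccc2Br)cc(OC)c1OC` gives 190 nM
- compound 2 `COc1cc(C(=O)c2cn(-c3ccccc3)cc2-c2ccccc2[N+](=O)[O-])cc(OC)c1OC` gives 49 nM

Compound 2 at 49 nM holds the lower of the two numbers. Compound 3 `COc1cc(C(=O)c2cn(-c3ccccc3)cc2-c2cc(F)ccc2F)cc(OC)c1OC` carries 2,5-difluorophenyl in place of 2-nitrophenyl on an aromatic carbon. Among the measured compounds shown here, the one measured step bears on this only indirectly: nitro in place of bromo gave a 3.9-fold lower number from compound 1 to compound 2 (0.59 log units; beyond the scatter) and lies beyond the scatter. With the nitro group of compound 2 leaving, a modest step toward a higher number is expected in this assay and the data offer no closer guide. The estimated step is a 2.2-fold higher number from compound 2 to compound 3 (0.35 log units; beyond the scatter) as a working expectation. Compound 3 is estimated at 110 nM (range 35 nM to 350 nM).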

Compound 3, half-maximal inhibitory concentration: 230 nM
Compound 3: the middle estimate sits 2.1-fold (0.32 log units) below what was measured, within the range that was stated.
By their numbers in this assay, from the lowest: compound 2; then compounds 1 and 3 (each within the scatter of the next).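

In this assay the change from 2-nitrophenyl to 2,5-difluorophenyl on this aromatic carbon gives a 4.7-fold higher number from compound 2 to compound 3 (0.67 log units; beyond the scatter) and does not keep the lower number of compound 2. The change from 2-bromophenyl to 2,5-difluorophenyl gives a 1.2-fold higher number from compound 1 to compound 3 (0.08 log units; within the scatter) so that, of the three groups at this position, only 2-nitrophenyl separates from the others. Nothing available accounts for this difference.

From the compounds shown here alone, how an amine or a nitrile on this phenyl ring would compare with the nitro group of compound 2 stays open. So does whether a nitro group elsewhere on that ring would give a similar number.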